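The source may report more compounds than this note shows. Statements on the series, on what has been measured and on what is new or still open speak of the compounds shown alone.

Measured so far:
Compound 1 `CCN(CC)S(=O)(=O)c1ccc(S(=O)(=O)N2CCC[C@@H](C(=O)NC3COC3)C2)cc1` gives 2340 nM in a functional assay on MIA PaCa-2 cells (Homo sapiens) for inhibition, read by MTT assay, with a stated time of 7 days; on this read-out lower numbers stand for stronger inhibition and higher numbers for weaker inhibition.
Compound 2 `CCN(CC)S(=O)(=O)c1ccc(S(=O)(=O)N2CCC[C@@H](C(=O)N[C@H]3CC[C@H](OC)CC3)C2)cc1` gives 1350 nM in this assay.
Compound 3 `CCN(CC)S(=O)(=O)c1ccc(S(=O)(=O)N2CCC[C@@H](C(=O)N3CCC(C(F)(F)F)CC3)C2)cc1` gives 320 nM in this assay.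

Compound 3 has the lowest number of the three, and both of its steps are beyond the scatter: a 7.3-fold lower number from compound 1 to compound 3 (0.86 log units; beyond the scatter) and a 4.2-fold lower number from compound 2 to compound 3 (0.63 log units; beyond the scatter). The step of a 1.7-fold lower number from compound 1 to compound 2 (0.24 log units; within the scatter) lies within the scatter, so compounds 1 and 2 cannot be ranked against each other.

Compound 4 `CCN(CC)S(=O)(=O)c1ccc(S(=O)(=O)N2CCC[C@@H](C(=O)N3CC[C@@H](OC)C3)C2)cc1` is the next compound. It differs from compound 3 in one place: 3-methoxypyrrolidin-1-yl in place of 4-(trifluoromethyl)piperidin-1-yl on a carbonyl carbon. Like compound 3, compound 4 carries a saturated nitrogen ring on the carbonyl carbon, whereas compounds 1 and 2 carry an amino group there. The two steps that bear on the change are therefore a 7.3-fold lower number from compound 1 to compound 3 (0.86 log units; beyond the scatter) and a 4.2-fold lower number from compound 2 to compound 3 (0.63 log units; beyond the scatter), which together suggest that the ring on the carbonyl carbon matters. The methoxy group of compound 4 resembles that of compound 2, whose number sits well above compound 3, and the trifluoromethyl group is lost. A modest rise in the number is expected, so compound 4 is estimated to give 800 nM in this assay, within a range of 300 nM to 2500 nM, an expected step of a 2.5-fold higher number from compound 3 to compound 4 (0.40 log units; beyond the scatter).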

Compound 4, half-maximal inhibitory concentration: 3910 nM
Estimate against measurement, compound 4: 4.9-fold (0.69 log units) below; measured number outside the range, above it.
By their numbers in this assay, from the lowest: compound 3; then compounds 2, 1 and 4 (each within the scatter of the next, the first and the last beyond it).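

Going by these compounds alone, until now the only compound with a saturated nitrogen ring on the carbonyl carbon was also the one with the lowest number, so the ring itself could have seemed to be what mattered. Compound 4 separates the two: in this assay the change from 4-(trifluoromethyl)piperidin-1-yl to 3-methoxypyrrolidin-1-yl gives a large loss (a 12-fold higher number from compound 3 to compound 4 (1.09 log units; beyond the scatter)), and having such a ring on the carbonyl carbon is clearly not enough on its own. Compound 4 also gives a higher number than the amide compound with 4-methoxycyclohexyl (a 2.9-fold higher number from compound 2 to compound 4 (0.46 log units; beyond the scatter)) and cannot be ranked against the amide compound with oxetan-3-yl (a 1.7-fold higher number from compound 1 to compound 4 (0.22 log units; within the scatter)), and no measured information on any property of these groups is available to explain the result.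

This single change alters both the ring size and the group on the ring, so a 4-methoxypiperidin-1-yl or a 3-(trifluoromethyl)pyrrolidin-1-yl group would be needed to tell the two effects apart. Only one arrangement at the defined stereocentre of 3-methoxypyrrolidin-1-yl is shown, so whether that arrangement affects the number also stays open.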